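The source may report more compounds than this note shows. Statements on the series, on what has been measured and on what is new or still open speak of the compounds shown alone.

Compound 2 `COc1ccc(-c2cc(=O)c3c(OC)cc(OC)cc3n2S(=O)(=O)c2ccc(Cl)cc2)cc1` in a functional assay on SUP-B15 cells (Homo sapiens) for antiproliferative activity, with a stated time of 72 h (on this read-out higher numbers stand for an effect only at larger amounts of compound and lower numbers for an effect already at smaller amounts), gives only a limit of the assay, > 34400 nM. Its closest measured neighbour, compound 1 `COc1ccc(-c2cc(=O)c3c(OC)cc(OC)cc3n2S(=O)(=O)c2ccc([N+](=O)[O-])cc2)cc1`, gives 17100 nM in this assay. For the measured compounds named here, the single measured step, an at least 2.0-fold higher number from compound 1 to compound 2 (0.30 log units; that floor lies within the scatter), is therefore itself uncertain, resting on (the limit of > 34400 nM in this assay, at which 1 of the 2 values shown sits). Compound 3 `COc1ccc(-c2cc(=O)c3c(OC)cc(OC)cc3n2S(=O)(=O)c2cccc(Br)c2)cc1` differs from compound 2 by 3-bromophenyl in place of 4-chlorophenyl on a sulfonyl sulfur. Going by the values given here, no measured step alters that ring in the same way, so the expectation for compound 3 is a step that the limit leaves unreadable from compound 2 to compound 3 that stays within the scatter, giving an estimated 40000 nM with a range from 15000 nM to 110000 nM, quite possibly again reported only as a limit.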

Compound 3, half-maximal effective concentration: > 58600 nM
Compound 3: no number, only a limit; the forecaster's own chance of this, stated with the estimate: 60%; middle value at least 1.4-fold (0.16 log units) from the limit.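

For the compounds shown here, replacing 4-nitrophenyl with 3-bromophenyl on the sulfonyl sulfur gives, in this assay, an at least 3.4-fold higher number from compound 1 to compound 3 (0.53 log units; beyond the scatter) and is the first step here to clear the scatter. That size is only a floor, set by a limit of the assay for compound 3: the limit of > 58600 nM in this assay, at which 1 of the 3 values shown sits. Compound 2 and compound 3 both give only limits, so the step between them cannot be read.

From the compounds shown here alone, how an amine or a carboxylic acid on this phenyl ring would read in this assay stays open.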